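Swapping the pyridinyl amide for an aminoindazole

The compounds below may be only part of what the source reports. "The series", "measured", "known", "first", "only" and "open" are said of these compounds alone.

Compound 1 `O=C(Nc1ccc(-c2cn([C@@H]3CN[C@H](C(=O)Nc4ccc(Cl)c(C(F)(F)F)c4)C3)nn2)cn1)C1CC1` gives 8770 nM
Compound 2 `CCN(CC)C(=O)c1cncc(-c2cn([C@@H]3CN[C@H](C(=O)Nc4ccc(Cl)c(C(F)(F)F)c4)C3)nn2)c1` gives 27600 nM
Compound 3 `CC(C)(C)OC(=O)N1C[C@@H](n2cc(-c3ccc4c(N)n[nH]c4c3)nn2)C[C@H]1C(=O)Nc1ccc(Br)cc1` gives 3710 nM

In a functional assay on K562 cells (Homo sapiens) for inhibition, read by MTT assay, with a stated time of 48 h (a higher number here means a weaker inhibitor, a lower number a stronger inhibitor), compound 1 holds the middle place of the three numbers, with compound 3 lower and compound 2 higher, both gaps beyond the usual scatter. Compound 4 `Nc1n[nH]c2cc(-c3cn([C@@H]4CN[C@H](C(=O)Nc5ccc(Cl)c(C(F)(F)F)c5)C4)nn3)ccc12` is still unmeasured. It carries 3-amino-1H-indazol-6-yl in place of 6-((cyclopropylcarbonyl)amino)pyridin-3-yl on an aromatic carbon. Compound 3 also carries 3-amino-1H-indazol-6-yl and gives 3710 nM in this assay but differs from compound 4 elsewhere, so it is only a loose guide. The expected step of a 1.9-fold lower number from compound 1 to compound 4 (0.29 log units; within the scatter) is small and points to a lower number. Compound 4 is estimated at 4500 nM (expected range 1500 nM to 14000 nM).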

Compound 4, half-maximal inhibitory concentration: 8320 nM
Compound 4: the middle estimate sits 1.8-fold (0.27 log units) below what was measured, and the stated range covers the measured number.
By their numbers in this assay, from the lowest: compound 3; then compounds 4 and 1 (each within the scatter of the next); then compound 2.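

In this assay, putting 3-amino-1H-indazol-6-yl in place of 6-((cyclopropylcarbonyl)amino)pyridin-3-yl gives a 1.1-fold lower number from compound 1 to compound 4 (0.02 log units; within the scatter), so the two groups cannot be told apart at this position. This aromatic carbon therefore accepts either a group with a three-membered carbon ring or one with a five-membered aromatic ring, with no readable change in the number. Nothing at hand explains this match.

Still open, from the compounds shown here alone, is whether a simple amine or a carboxylic acid on this carbon would give a similar number. Also open, going by these compounds, is whether 1H-indazol-6-yl without its amino group would match 3-amino-1H-indazol-6-yl.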